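Tetrazole in Place of Oxadiazole on the Carbonyl

This account rests on a few compounds, and the source may have more. Where it says the series, first, only, none or still open, it means among the compounds named here.

Three measured compounds share the core of compound 2 `O=C(CCCCCCc1ccccc1)c1ncon1` and differ only in the small aromatic ring attached to the carbonyl carbon. In an assay on isolated protein for inhibition of neutral cholesterol ester hydrolase 1 (Homo sapiens) (a lower number here means a stronger inhibitor, a higher number a weaker inhibitor), compound 1 `COC(=O)c1cccc(-c2noc(C(=O)CCCCCCc3ccccc3)n2)n1` gives 40000 nM. Compound 2 gives only a limit of the assay, > 100000 nM. Compound 3 `O=C(CCCCCCc1ccccc1)c1noc(-c2ccccn2)n1` likewise gives only a limit, > 100000 nM. The step from compound 2 to compound 3 is a step that the two limits leave unreadable from compound 2 to compound 3, so that change yields no readable size. Where compound 2 stands is set by the limit of > 100000 nM in this assay, at which 2 of the 3 values shown sit: it has no number of its own, only the limit.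

Compound 4 `O=C(CCCCCCc1ccccc1)c1nnn[nH]1` differs from compound 2 by 1H-tetrazol-5-yl in place of 1,2,4-oxadiazol-3-yl on a carbonyl carbon. Going by the values given here, no measured step alters the ring on the carbonyl carbon in this way, and the single step that starts from compound 2 is unreadable, so no size can be carried over to this change. Compound 4 is therefore expected to sit near the limit as well, at 100000 nM, with a range from 30000 nM to 300000 nM. The expected step is a number no higher from compound 2 to compound 4 (the limit leaves the size open), nothing beyond the scatter.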

Compound 4, half-maximal inhibitory concentration: 60000 nM
Compound 4: the middle estimate sits 1.7-fold (0.22 log units) above what was measured; the measured number falls inside the stated range.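

Placing 1H-tetrazol-5-yl instead of 1,2,4-oxadiazol-3-yl on the carbonyl carbon gives the only step from compound 2 with a readable size, and in this assay it is an at least 1.6-fold lower number from compound 2 to compound 4 (0.22 log units; that floor lies within the scatter). This size is only a floor, and the true change could be larger: the limit of > 100000 nM in this assay, at which 2 of the 4 values shown sit. The change also brings in a hydrogen-bond donor, but this single pair cannot show whether the donor or some other difference between the two rings accounts for the number that compound 4 gives.

Where compound 2 truly stands remains unknown, so the full size of this step stays open. From the compounds shown here alone, it is also open whether a carboxylic acid on the carbonyl carbon, or a longer chain on the other side of the carbonyl, would give a lower number than compound 4.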